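This account rests on a few compounds, and the source may have more. Where it says the series, first, only, none or still open, it means among the compounds named here.

Two compounds of this series have been run in a functional assay on MCF7 cells (Homo sapiens) for antiproliferative activity, read by MTT assay, with a stated time of 72 h; a higher number here means a weaker inhibitor, a lower number a stronger inhibitor. Compound 1 `CC1=CC[C@H]2[C@H](CC[C@]2(C)O)C(C)(C)[C@@H]1CC[C@H]1[C@]2(C)CC[C@H](OC(=O)c3ccc(C)cc3)C(C)(C)O[C@H]2CC[C@@]1(C)O` gives only a limit of the assay, > 50000 nM, and no number, as the limit of > 50000 nM in this assay, at which 1 of the 2 values shown sits, records. Going by the values given here, compound 2 `CC(=O)O[C@H]1CC[C@]2(C)[C@H](CC[C@@](C)(O)[C@H]2CC[C@@H]2C(C)=CC[C@@H]3C(C)=CC[C@@H]3C2(C)C)OC1(C)C` is the sole compound with a numerical value, 43500 nM, which is weak inhibition. Compound 3 `CC1=CC[C@H]2[C@@H]1CC=C(C)[C@@H](CC[C@H]1[C@]3(C)CC[C@H](OC(=O)c4ccncc4)C(C)(C)O[C@H]3CC[C@@]1(C)O)C2(C)C` carries pyridin-4-yl in place of methyl on a carbonyl carbon. Among the compounds with values here, no step between measured compounds is available to anchor this change. The step of a 1.1-fold lower number from compound 2 to compound 3 (0.04 log units; within the scatter) is expected to stay within the usual scatter. Compound 3 is therefore estimated at 40000 nM, with a range from 15000 nM to 90000 nM.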

Compound 3, half-maximal inhibitory concentration: > 50000 nM
Compound 3: only a limit was reported; the forecaster's own chance of this, stated with the estimate: 40%; middle value at least 1.2-fold (0.09 log units) away from the limit.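

Pyridin-4-yl in place of methyl on a carbonyl carbon gives an at least 1.1-fold higher number from compound 2 to compound 3 (0.06 log units; that floor lies within the scatter) in this assay and so brings no lower number at this position. Compound 3 gives only a limit of the assay, so the true size of the step cannot be read: the limit of > 50000 nM in this assay, at which 2 of the 3 values shown sit. The six-membered aromatic ring is therefore not enough here to yield a measurable gain over the acetoxy of compound 2.

On these data alone, whether a longer chain in place of methyl would keep a numerical value stays open. So does whether an amine or a carboxylic acid on the ring would change the reading.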